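Phenyl in place of propargyl: working notes

The source may hold more compounds than are shown below. What is called first, only, known or untested is meant among the compounds shown, and "the series" means these compounds.

Measured so far in a functional assay on SK-MEL-2 cells (Homo sapiens) for inhibition; on this read-out lower numbers stand for stronger inhibition and higher numbers for weaker inhibition
- compound 1 `CCCCCOC(=O)Nc1nc(=O)n(C2O[C@H](C(=O)O)[C@@H](O)[C@H]2O)cc1F` gives 0.03 ug/mL
- compound 2 `C=CCOC(=O)Nc1nc(=O)n(C2O[C@H](C(=O)O)[C@@H](O)[C@H]2O)cc1F` gives 0.008 ug/mL
- compound 3 `C#CCOC(=O)Nc1nc(=O)n(C2O[C@H](C(=O)O)[C@@H](O)[C@H]2O)cc1F` gives 0.007 ug/mL

Compound 3 shares the low end of these numbers with compound 2. Compound 4 `O=C(Nc1nc(=O)n(C2O[C@H](C(=O)O)[C@@H](O)[C@H]2O)cc1F)Oc1ccccc1` differs from compound 3 by phenyl in place of propargyl on an oxygen next to a carbonyl group, with phenyl in place of propargyl on an oxygen next to a carbonyl group. The nearest evidence is a 3.8-fold lower number from compound 1 to compound 2 (0.57 log units; beyond the scatter) and a 4.3-fold lower number from compound 1 to compound 3 (0.63 log units; beyond the scatter), both modest, and a 1.1-fold lower number from compound 2 to compound 3 (0.06 log units; within the scatter), within the scatter. None of these steps brings in an aromatic ring, so they bear only indirectly. A small rise in this assay is expected, probably not beyond the scatter. The expected step is a 1.7-fold higher number from compound 3 to compound 4 (0.23 log units; within the scatter) for this change. For compound 4 the estimate is 0.012 ug/mL, with an expected range of 0.004 ug/mL to 0.04 ug/mL for the measurement.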

Compound 4, half-maximal inhibitory concentration: 0.1 ug/mL
Beside the measured number, compound 4's estimate is 8.3-fold (0.92 log units) below it, and the stated range ends below it.
By their numbers in this assay, from the lowest: compounds 3 and 2 (each within the scatter of the next); then compound 1; then compound 4.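

In this assay, among the compounds shown here, phenyl on an oxygen next to a carbonyl group gives a much larger rise than the earlier steps at this position, with a 14-fold higher number from compound 3 to compound 4 (1.15 log units; beyond the scatter) and a 13-fold higher number from compound 2 to compound 4 (1.10 log units; beyond the scatter) both large. The aromatic ring also ends above the saturated chain, with a 3.3-fold higher number from compound 1 to compound 4 (0.52 log units; beyond the scatter) as a modest step, so the low numbers of the propargyl and allyl compounds do not carry over to phenyl. No available data explain this rise. On these data alone, whether a benzyl group or a cyclohexyl ring on this oxygen would restore the low numbers of compound 2 and compound 3 remains open.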